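Return of an aromatic ring on the amide side chain

The source may report more compounds than this note shows. Statements on the series, on what has been measured and on what is new or still open speak of the compounds shown alone.

The series shares the core of compound 1 `COc1cc(CC(C)C(=O)N2CCN(c3ccc(C(F)(F)F)cc3[C@@H](N)CC(C)C)CC2)ccc1Cl`, which in an assay on HEK293 cells for displacement of a labelled ligand from Melanocortin receptor 4 (Homo sapiens) (a higher number here means a weaker inhibitor, a lower number a stronger inhibitor), gives 230 nM. Compound 2 `CC(C)C[C@H](N)c1cc(F)ccc1N1CCN(C(=O)C(C)Cc2ccc(Cl)cc2)CC1` gives 390 nM in this assay. Compound 3 `CC(C)C[C@H](N)c1cc(C(F)(F)F)ccc1N1CCN(C(=O)CCC2CCCCC2)CC1` gives 5700 nM, the highest of the three numbers; its nearest neighbour is compound 2 with a smaller number, the furthest is compound 1, and both gaps lie beyond the scatter. Within the data shown here, the only single-point step among the measured compounds is a 25-fold higher number from compound 1 to compound 3 (1.39 log units; beyond the scatter), a large rise on exchanging the aryl-bearing chain for 2-cyclohexylethyl.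

Compound 4 `CC(C)C[C@H](N)c1cc(C(F)(F)F)ccc1N1CCN(C(=O)CSc2ccc(Cl)cc2Cl)CC1` is not yet measured. Relative to compound 3 the change is (2,4-dichlorophenyl)sulfanyl in place of cyclohexylmethyl on a saturated chain carbon bound to a carbonyl carbon. Among the measured compounds shown here, this bears directly on the one measured step: the 2-cyclohexylethyl group behind the rise a 25-fold higher number from compound 1 to compound 3 (1.39 log units; beyond the scatter) gives way to a chain ending in a six-membered aromatic ring of carbon only carrying two chlorines, recalling the chlorophenyl-bearing chains of compounds 1 and 2. The expectation is therefore a step back down in this assay, of a size comparable to that rise, so compound 4 is expected to come out at 400 nM (range 120 nM to 1500 nM), an estimated step of a 14-fold lower number from compound 3 to compound 4 (1.15 log units; beyond the scatter). For the measured compounds named here, whether the sulfur link and the second chlorine shift the number beyond the scatter cannot be told from the present compounds; compound 4 is the first with either.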

Compound 4, inhibition constant: 1500 nM
Compound 4: middle estimate off by 3.8-fold (0.57 log units), on the low side, within the range that was stated.
By their numbers in this assay, from the lowest: compounds 1 and 2 (each within the scatter of the next); then compound 4; then compound 3.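

In this assay the aromatic group takes back only part of the rise: (2,4-dichlorophenyl)sulfanyl in place of cyclohexylmethyl on a saturated chain carbon bound to a carbonyl carbon gives a 3.8-fold lower number from compound 3 to compound 4 (0.58 log units; beyond the scatter), a modest step set against the large 25-fold higher number from compound 1 to compound 3 (1.39 log units; beyond the scatter). The recovery is incomplete, since ((2,4-dichlorophenyl)sulfanyl)methyl in place of 1-(4-chloro-3-methoxybenzyl)ethyl on a carbonyl carbon leaves a 6.5-fold higher number from compound 1 to compound 4 (0.81 log units; beyond the scatter), so in this pair an aromatic ring on the side chain does not by itself return the number to that of compound 1. No measurement at hand accounts for the size of either step.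

The sulfur link, the aromatic ring and the second chlorine all enter in one step, so their shares remain unresolved; a methylene in place of the sulfur, or 4-chlorophenyl in place of 2,4-dichlorophenyl, would divide that step. Also open, going by these compounds, is how this position responds to a different kind of group, such as an amine or a carboxylic acid on the same saturated chain carbon.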